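The source may report more compounds than this note shows. Statements on the series, on what has been measured and on what is new or still open speak of the compounds shown alone.

Values from a functional assay on the whole organism for inhibition, with Scenedesmus acutus as the target (on this read-out lower numbers stand for stronger inhibition and higher numbers for weaker inhibition), for the measured members of the series:

- compound 1 `S=c1n(-c2ccc(Cl)cc2)c(=S)n2n1CCCC2`: 61.7 nM
- compound 2 `Fc1cc(Cl)ccc1-n1c(=S)n2n(c1=S)CCCC2`: 23.4 nM
- compound 3 `S=c1s/c(=N\c2ccc(Cl)cc2)n2n1CCCC2`: 339 nM

Compound 1 and compound 2 share one core. Compound 2 differs from compound 1 by a single change, (fluoro in place of hydrogen on an aromatic carbon), and this change gave a 2.6-fold lower number from compound 1 to compound 2 (0.42 log units; beyond the scatter). The change occurs once among the measured pairs, so its effect rests on this pair alone.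

Compound 3 is built from the same atoms as compound 1, joined differently; the difference between the two cores is not broken down here. In this assay compound 3 gives the highest of the three numbers, and both the step to compound 1 and the step to compound 2 lie beyond the scatter.

Compound 4 `Fc1cc(Cl)ccc1/N=c1\sc(=S)n2n1CCCC2` is not yet measured. It differs from compound 3 by fluoro in place of hydrogen on an aromatic carbon, the same change as from compound 1 to compound 2, made on the core of compound 3 instead. Carrying the change across, a step of a 2.6-fold lower number from compound 3 to compound 4 (0.42 log units; beyond the scatter) is expected from compound 3 to compound 4, resting on a 2.6-fold lower number from compound 1 to compound 2 (0.42 log units; beyond the scatter). Because this rests on a 2.6-fold lower number from compound 1 to compound 2 (0.42 log units; beyond the scatter) from a single pair on a different core, the range is kept wide. The expected value for compound 4 in this assay is 130 nM, with an estimated range from 50 nM to 340 nM.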

Compound 4, half-maximal inhibitory concentration: 120 nM
Beside the measured number, compound 4's estimate is 1.1-fold (0.03 log units) above it, and the stated range covers the measured number.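

Fluoro in place of hydrogen on an aromatic carbon, ortho to a large group and meta to a chloro group, gives in this assay a 2.8-fold lower number from compound 3 to compound 4 (0.45 log units; beyond the scatter), and this step agrees in size with the earlier one on the other core: the same change on two cores in this assay, a 2.6-fold lower number (0.42 log units; beyond the scatter) from compound 1 to compound 2 and a 2.8-fold lower number (0.45 log units; beyond the scatter) from compound 3 to compound 4, 1.1-fold (0.03 log units) apart, within the scatter of two such steps

In this assay, the change therefore carries from the core of compound 1 to the core of compound 3 with no difference in size that stands out from the scatter, and on both cores the fluoro compound gives the lower number. Among these compounds, this rests on only two pairs, both with the same chloro group on the aromatic ring and both read in one assay, so it shows neither that the step holds on other cores nor why it occurs.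

The compounds shown leave open whether a methyl, methoxy or second chloro group in place of the fluoro would carry between these two cores in the same way. They also leave open whether fluoro gives a step of similar size when the chloro group is replaced by another group, such as trifluoromethyl, or is absent.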